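This account rests on a few compounds, and the source may have more. Where it says the series, first, only, none or still open, it means among the compounds named here.

Measured so far in a functional assay on OVCAR-3 cells (Homo sapiens) for antiproliferative activity, read by spectrophotometry, with a stated time of 2 days; a higher number here means a weaker inhibitor of growth, a lower number a stronger inhibitor of growth:

- compound 1 `COc1ccc(Nc2ncc(C(F)(F)F)c(N3Cc4cccc(N(C)S(C)(=O)=O)c4C3)n2)cc1C(F)(F)F`: > 30000 nM (a limit of the assay, not a number)
- compound 2 `CC(=O)N1CCN(c2ccc(Nc3ncc(C(F)(F)F)c(N4Cc5cccc(N(C)S(C)(=O)=O)c5C4)n3)cc2)CC1`: 970 nM

Compound 1 has no exact place on this scale, only a limit: the limit of > 30000 nM in this assay, at which 1 of the 2 values shown sits. Among the compounds with values here, compound 2 is the only one of the pair with a true number, at 970 nM.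

Compound 3 `COc1cc(Nc2ncc(C(F)(F)F)c(N3Cc4cccc(N(C)S(C)(=O)=O)c4C3)n2)cc(OC)c1` has not yet been measured. It keeps the core of compound 1 and changes one group, with 3,5-dimethoxyphenyl in place of 4-methoxy-3-(trifluoromethyl)phenyl on a nitrogen on an aromatic ring. It does not take up the group that compound 2 carries there. One substituted phenyl simply replaces another, so only a modest gain in this assay is expected, if any shows at all. The expected change is an at least 2.0-fold lower number from compound 1 to compound 3 (0.30 log units; that floor lies within the scatter), in the direction of stronger inhibition of growth. Compound 3 could also end up reported only as a limit. For compound 3 the estimate is 15000 nM, with an expected range from 4000 nM to 30000 nM.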

Compound 3, concentration for 50% growth inhibition: 630 nM
Compound 3: the middle estimate sits 24-fold (1.38 log units) above what was measured; the measured number lies below the stated range.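

In this assay, with the core held fixed, the group on the nitrogen on an aromatic ring proves decisive on its own: 3,5-dimethoxyphenyl in place of 4-methoxy-3-(trifluoromethyl)phenyl gives an at least 47-fold lower number from compound 1 to compound 3 (1.67 log units; beyond the scatter). A true number at this position also does not depend on the group that compound 2 carries there, as compound 2 gives 970 nM with that group and compound 3 gives 630 nM with a plain dimethoxy-substituted phenyl instead. The size of the step is only a floor, since compound 1 is reported as a limit of the assay and not as a number: the limit of > 30000 nM in this assay, at which 1 of the 3 values shown sits.

Both substituents on the ring change in this swap, so the compounds shown leave open whether the step comes from losing the trifluoromethyl, from gaining the second methoxy, or from the two together. They also leave open how a phenyl ring carrying an amine or a carboxylic acid, or a longer chain in place of methoxy, would read in this assay.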